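The source may hold more compounds than are shown below. What is called first, only, known or untested is meant among the compounds shown, and "the series" means these compounds.

Measured compounds:

Compound 1 `Cc1ccc(S(=O)(=O)Nc2cc[nH]c(=O)n2)cc1` — in a functional assay on NCI-H460 cells (Homo sapiens) for inhibition, read by MTT assay, with a stated time of 72 h (a higher number here means a weaker inhibitor, a lower number a stronger inhibitor), compound 1 gives > 100000 nM, which is a limit of the assay and not a number.
Compound 2 `N[C@H](CSCC(=O)Nc1c[nH]c(=O)[nH]c1=O)C(=O)O` — in this assay compound 2 gives > 100000 nM, again a limit.
Compound 3 `Cn1cc(CO)c(N)nc1=O` — in this assay compound 3 gives > 100000 nM, again a limit.

Compound 1 therefore stands nowhere distinct on the numbers shown: every value of the set sits at the limit of > 100000 nM in this assay, at which 3 of the 3 values shown sit, so no step within the measured compounds can be sized, and nothing in the data separates the three.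

Compound 4 `Cc1ccc(S(=O)(=O)Nc2ccn(C)c(=O)n2)cc1` differs from compound 1 by methyl in place of hydrogen on an aromatic nitrogen. For the measured compounds named here, no measured step informs this change; with the parent at the limit, no movement beyond the scatter is expected, and the step that the limit leaves unreadable from compound 1 to compound 4 is an estimate only. Compound 4 is expected to give about 150000 nM, within 30000 nM to 600000 nM, most likely reported again as a limit.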

Compound 4, half-maximal inhibitory concentration: > 100000 nM
Compound 4: no number, only a limit (the forecaster's own chance of this, stated with the estimate: 85%); the middle value does not contradict the limit.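

No step can be read from compound 1 to compound 4, as both values are limits and not numbers: the limit of > 100000 nM in this assay, at which 4 of the 4 values shown sit.

The compounds shown leave open whether methyl in place of hydrogen on an aromatic nitrogen changes inhibition at all, and what would bring any compound to a measurable value.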